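Allyloxy analogue of the benzyloxy compound: expected potency

This account rests on a few compounds, and the source may have more. Where it says the series, first, only, none or still open, it means among the compounds named here.

Compound 1 `CCO/N=C/c1c(N)ncnc1Oc1ccc2[nH]c(C)cc2c1F` gives 32 nM in a functional assay on HeLa cells (Homo sapiens) for antiproliferative activity; a higher number here means a weaker inhibitor, a lower number a stronger inhibitor. Compound 2 `Cc1cc2c(F)c(Oc3ncnc(N)c3/C=N/OCCCO)ccc2[nH]1` gives 362 nM in this assay, and compound 3 `Cc1cc2c(F)c(Oc3ncnc(N)c3/C=N/OCc3ccccc3)ccc2[nH]1` gives 266 nM in this assay. Of the three numbers that of compound 3 is the second highest; its nearest neighbour is compound 2, within the scatter, and the furthest is compound 1, with an 8.3-fold higher number from compound 1 to compound 3 (0.92 log units; beyond the scatter). Compound 4 `C=CCO/N=C/c1c(N)ncnc1Oc1ccc2[nH]c(C)cc2c1F` differs from compound 3 by vinyl in place of phenyl on a saturated chain carbon bound to an oxygen. The step that bears most on this is an 8.3-fold higher number from compound 1 to compound 3 (0.92 log units; beyond the scatter), where phenyl replaced methyl at the same carbon; the step of an 11-fold higher number from compound 1 to compound 2 (1.05 log units; beyond the scatter) points the same way for another enlargement of the chain, while a 1.4-fold lower number from compound 2 to compound 3 (0.13 log units; within the scatter) lies within the scatter. Compound 4 carries the group with fewer heavy atoms at that carbon, so a lower number in this assay is expected for compound 4, a 3.3-fold lower number from compound 3 to compound 4 (0.52 log units; beyond the scatter), though not a full return to the level of compound 1. Compound 4 is therefore estimated at 80 nM in this assay, between 30 nM and 250 nM.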

Compound 4, half-maximal inhibitory concentration: 42 nM
For compound 4 the middle estimate is 1.9-fold (0.28 log units) above the measured one; the measured number falls inside the stated range.
By their numbers in this assay, from the lowest: compounds 1 and 4 (each within the scatter of the next); then compounds 3 and 2 (each within the scatter of the next).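

In this assay the allyloxy chain parts from the two larger chains, with a 6.3-fold lower number from compound 3 to compound 4 (0.80 log units; beyond the scatter) and an 8.6-fold lower number from compound 2 to compound 4 (0.94 log units; beyond the scatter), while a 1.3-fold higher number from compound 1 to compound 4 (0.12 log units; within the scatter). The earlier compounds showed only losses when methyl on this saturated chain carbon was replaced, so vinyl is the one group shown there that stays within the scatter of compound 1, and a change at this carbon does not by itself cost activity. Nothing available here explains why vinyl and phenyl part so far at this carbon.

An ethyl group in place of vinyl would show whether the double bond matters or only the chain length. On these data alone, how far this tolerance extends also remains open for a longer chain, a cyclopropyl group or an amine at this carbon.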